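The source may hold more compounds than are shown below. What is called first, only, known or untested is meant among the compounds shown, and "the series" means these compounds.

Among the measured compounds shown here, compound 3 `CC(C(=O)NCc1ccc(Cl)c(Cl)c1)c1ccc(NS(C)(=O)=O)c(F)c1` gives 115 nM in a functional assay on CHO cells for antagonist activity at transient receptor potential cation channel subfamily V member 1 (Rattus norvegicus) (a lower number here means a stronger inhibitor, a higher number a weaker inhibitor), the lowest of the three numbers measured so far. Compound 1 `CC(C)(C)c1ccc(CNC(=O)C(C)(C)c2ccc(NS(C)(=O)=O)c(F)c2)cc1` gives 467 nM in this assay, and compound 2 `CC(C)(C)c1ccc(CNC(=O)C2(c3ccc(NS(C)(=O)=O)cc3)CC2)cc1` gives 1770 nM in this assay; both gaps to compound 3 lie beyond the scatter, so compound 3 stands as the strongest inhibitor of the three.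

Compound 4 `CC(C(=O)NCc1ccc(C2CC2)cc1)c1ccc(NS(C)(=O)=O)c(F)c1` has not yet been measured. It differs from compound 3 in one place: 4-cyclopropylphenyl in place of 3,4-dichlorophenyl on a saturated chain carbon bound to an amide-type nitrogen. For the measured compounds named here, no two measured compounds differ by this same change, so there is no measured step that shows directly what it does, and compound 1 and compound 2 differ from compound 3 in more than one place, which keeps their numbers from serving as a guide.

With only the structural change to go on, the step of a 2.6-fold higher number from compound 3 to compound 4 (0.42 log units; beyond the scatter) is expected to be small, in the direction of a somewhat weaker inhibitor. For compound 4 the estimate in this assay is 300 nM, with a likely range from 80 nM to 1200 nM.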

Compound 4, inhibition constant: 55.5 nM
Estimate against measurement, compound 4: 5.4-fold (0.73 log units) above; measured number below the stated range.
By their numbers in this assay, from the lowest: compound 4; then compound 3; then compound 1; then compound 2.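

In this assay, 4-cyclopropylphenyl in place of 3,4-dichlorophenyl on a saturated chain carbon bound to an amide-type nitrogen gives a 2.1-fold lower number from compound 3 to compound 4 (0.32 log units; beyond the scatter), a modest gain in strength. Among the compounds shown here, this is the first direct reading of a change at this place, and it shows that the two chlorine atoms are not needed to keep this level of inhibition. A group made only of carbon, carrying a three-membered ring on its aromatic ring, makes compound 4 the stronger inhibitor of the pair.

From the compounds shown here alone, what an amine or a methoxy group would do at this place, in place of the cyclopropyl ring, stays open. The compounds shown offer no measurement that explains the gain from this change.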